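Amide acyl swap on the octadecyl threonine amide

The source may report more compounds than this note shows. Statements on the series, on what has been measured and on what is new or still open speak of the compounds shown alone.

Measured so far in a functional assay on MCF7 cells (Homo sapiens) for cytotoxicity, read by MTT assay, with a stated time of 48 h; a higher number here means a weaker inhibitor, a lower number a stronger inhibitor:
compound 1, `CCCCCCCCCCCCNC(=O)[C@@H](NC(=O)/C=C/c1ccccc1)[C@@H](C)O`: > 200000 nM
compound 2, `CCCCCCCCCCCCCCNC(=O)[C@@H](NC(=O)/C=C/c1ccccc1)[C@@H](C)O`: 64600 nM
compound 3, `CCCCCCCCCCCCCCCCCCNC(=O)[C@@H](NC(=O)c1cc2ccccc2o1)[C@@H](C)O`: 126000 nM

The value of compound 1 is a limit of this assay, not a number (the limit of > 200000 nM in this assay, at which 1 of the 3 values shown sits). Compound 3 and compound 2 sit within the scatter of each other, so no order between them can be read. Within the data shown here, the one step measured in one place is an at least 3.0-fold lower number from compound 1 to compound 2 (0.49 log units; beyond the scatter), which concerns the chain only and says nothing about the acyl group.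

Compound 4, `CCCCCCCCCCCCCCCCCCNC(=O)[C@@H](NC(=O)/C=C/c1ccccc1)[C@@H](C)O`, is the next entry. It differs from compound 3 by 2-phenylethenyl in place of 1-benzofuran-2-yl on a carbonyl carbon. Among the measured compounds shown here, no measured pair isolates this acyl change, so nothing bears on it directly; compound 2 carries the same acyl group on a shorter chain and gives 64600 nM. On that basis a step of no more than the scatter is expected, a 1.6-fold lower number from compound 3 to compound 4 (0.20 log units; within the scatter). Compound 4 is estimated at 80000 nM, within 30000 nM to 200000 nM.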

Compound 4, half-maximal inhibitory concentration: 39200 nM
Compound 4: middle estimate off by 2.0-fold (0.31 log units), on the high side, and the stated range covers the measured number.
By their numbers in this assay, from the lowest: compounds 4, 2 and 3 (each within the scatter of the next, the first and the last beyond it). At a limit, above all of these: compound 1.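

In this assay, the acyl group on the shared core now has a direct reading at fixed chain: a 3.2-fold lower number from compound 3 to compound 4 (0.51 log units; beyond the scatter), so on this chain the (2-phenylethenyl)carbonyl amide gives the lower number than the (1-benzofuran-2-yl)carbonyl amide. Among the 2-phenylethenyl amides, the chain difference yields a 1.6-fold lower number from compound 2 to compound 4 (0.22 log units; within the scatter), so no order can be read between these two chains. The step of an at least 5.1-fold lower number from compound 1 to compound 4 (0.70 log units; beyond the scatter) is only a bound, compound 1 standing at a limit of the assay: the limit of > 200000 nM in this assay, at which 1 of the 4 values shown sits.

Compound 3 is the only 1-benzofuran-2-yl amide shown, so whether the acyl difference holds on shorter chains remains open. Also open, as far as these compounds go, are a phenyl ring carrying an amine or a carboxylic acid, and a chain longer than that of compound 4.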